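This account rests on a few compounds, and the source may have more. Where it says the series, first, only, none or still open, it means among the compounds named here.

Values so far in a functional assay on HCT-116 cells (Homo sapiens) for antiproliferative activity, read by MTT assay, with a stated time of 48 h (a lower number here means a stronger inhibitor, a higher number a weaker inhibitor), are as follows
compound 1 `CCOc1cc(-c2ccc3cc[nH]c3c2)cn2c(-c3cc(OC)c(OC)c(OC)c3)nnc12` - 1340 nM
compound 2 `CCOc1cc(-c2ccc3c(ccn3C)c2)cn2c(-c3cc(OC)c(OC)c(OC)c3)nnc12` - 228 nM

Compound 2 holds the lower of the two numbers, and its gap to compound 1 lies beyond the scatter. For the measured compounds named here, the one measured step is a 5.9-fold lower number from compound 1 to compound 2 (0.77 log units; beyond the scatter) and it counts as modest. That step lies on an aromatic carbon and not on the oxygen at issue here, so it gives no direct size for the next change.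

Next comes compound 3 `COc1cc(-c2nnc3c(OC4CC4)cc(-c4ccc5c(ccn5C)c4)cn23)cc(OC)c1OC` with cyclopropyl in place of ethyl on an oxygen on an aromatic ring and in words cyclopropyl in place of ethyl on an oxygen on an aromatic ring, or ethoxy to cyclopropyloxy. Going by the values given here, no measured pair varies this group, so the estimate starts from compound 2 at 228 nM and carries a wide range. No step beyond the scatter is expected in this assay in either direction, and the estimated step is a 1.1-fold higher number from compound 2 to compound 3 (0.06 log units; within the scatter) with no firm direction. For compound 3 the estimated value is 260 nM with 90 nM to 750 nM as the expected range.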

Compound 3, half-maximal inhibitory concentration: 135 nM
The estimate for compound 3 lay 1.9-fold (0.28 log units) above the measured number, within the range that was stated.
By their numbers in this assay, from the lowest: compounds 3 and 2 (each within the scatter of the next); then compound 1.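

In this assay, for the compounds shown here, the first measured change on this oxygen on an aromatic ring reads a 1.7-fold lower number from compound 2 to compound 3 (0.23 log units; within the scatter), so ethoxy and cyclopropyloxy cannot be told apart at this position in this assay. Cyclopropyl brings one more carbon and a three-membered non-aromatic ring to the oxygen, and neither addition produces a step beyond the scatter, while the only such step so far, a 5.9-fold lower number from compound 1 to compound 2 (0.77 log units; beyond the scatter), lies at the other place, on an aromatic carbon. No measurement is available that bears on this result or explains it.

From the compounds shown here alone, the oxygen carries only ethyl and cyclopropyl in these compounds, both built of carbon alone, so it remains open whether a longer chain such as n-butyl, or a chain ending in an amine or a carboxylic acid, would also stay within the scatter or move the number beyond it. Also open, going by these compounds, is whether cyclopropyl in place of ethyl would read the same with 1H-indol-6-yl, the group in compound 1, in place of 1-methyl-1H-indol-5-yl.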